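From 4-vinylphenyl to 4-acetylphenyl: a small step expected

This account rests on a few compounds, and the source may have more. Where it says the series, first, only, none or still open, it means among the compounds named here.

Compound 1 `COc1cc(-c2ccnc3cc(-c4ccc5c(ccn5C)c4)nn23)cc(OC)c1OC` gives 15 nM
Compound 2 `COc1cc(-c2ccnc3cc(-c4ccc(C(F)(F)F)cc4)nn23)cc(OC)c1OC` gives 2070 nM
Compound 3 `C=Cc1ccc(-c2cc3nccc(-c4cc(OC)c(OC)c(OC)c4)n3n2)cc1` gives 1030 nM

These values come from a functional assay on A549 cells (Homo sapiens) for inhibition, read by CCK-8 assay, with a stated time of 48 h (on this read-out lower numbers stand for stronger inhibition and higher numbers for weaker inhibition), and share one core. Compound 3 stands far from compound 1 (a 69-fold higher number from compound 1 to compound 3 (1.84 log units; beyond the scatter)) but cannot be separated from compound 2 (a 2.0-fold lower number from compound 2 to compound 3 (0.30 log units; within the scatter)).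

Compound 4 `COc1cc(-c2ccnc3cc(-c4ccc(C(C)=O)cc4)nn23)cc(OC)c1OC` differs from compound 3 in one group: acetyl in place of vinyl on an aromatic carbon (acetyl in place of vinyl, para to a large group). Both large steps, including a 140-fold higher number from compound 1 to compound 2 (2.14 log units; beyond the scatter), replace the 1-methyl-1H-indol-5-yl group, which compound 3 and compound 4 both lack. Among the compounds with values here, the one measured swap at this place stayed within the scatter, so no step beyond the scatter is expected in this assay from this change, although that expectation rests on a single pair. The estimated step is small (a 1.2-fold higher number from compound 3 to compound 4 (0.07 log units; within the scatter)). Compound 4 is estimated at 1200 nM (range 400 nM to 3600 nM).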

Compound 4, half-maximal inhibitory concentration: 4100 nM
Beside the measured number, compound 4's estimate is 3.4-fold (0.53 log units) below it; the whole stated range lies below it.
By their numbers in this assay, from the lowest: compound 1; then compounds 3, 2 and 4 (each within the scatter of the next, the first and the last beyond it).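

In this assay, acetyl in place of vinyl, para to a large group, shows that a swap at this place can go beyond the scatter, with a 4.0-fold higher number from compound 3 to compound 4 (0.60 log units; beyond the scatter) as a modest step. Acetyl and trifluoromethyl still cannot be separated, with a 2.0-fold higher number from compound 2 to compound 4 (0.30 log units; within the scatter), and replacing 1-methyl-1H-indol-5-yl remains a far larger change, with a 270-fold higher number from compound 1 to compound 4 (2.44 log units; beyond the scatter) as the step. No evidence at hand explains the gap between acetyl and vinyl. As far as these compounds go, whether an amine or a carboxylic acid at this place would bring the number closer to that of compound 1 remains open.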